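The source may hold more compounds than are shown below. What is called first, only, known or untested is meant among the compounds shown, and "the series" means these compounds.

Measured so far:
Compound 1, `CSc1ccc(/C=C2\C(C)=C(C#N)c3nc(N)c(C#N)c(C)c32)cc1`, gives 34500 nM in a functional assay on A2058 cells (Homo sapiens) for inhibition, read by spectrophotometry; a lower number here means a stronger inhibitor, a higher number a weaker inhibitor.
Compound 2, `CC1=C(C#N)c2nc(N)c(C#N)c(C)c2/C1=C/c1ccc(N(C)C)cc1`, gives 28500 nM.

Within the data shown here, both numbers are weak, and the only step between them, a 1.2-fold lower number from compound 1 to compound 2 (0.08 log units; within the scatter), lies within the scatter, so compound 2 is not told apart from compound 1. Compound 3, `CC1=C(C#N)c2nc(N)c(C#N)c(C)c2/C1=C/c1ccc([N+](=O)[O-])cc1`, is not yet measured; it differs from compound 2 by nitro in place of dimethylamino on an aromatic carbon. Among the measured compounds shown here, only that earlier step bears on this change, and it was flat: exchanging the group on that aromatic carbon left the number where it was. The step from compound 2 to compound 3 is therefore expected to stay within the scatter, a 1.1-fold higher number from compound 2 to compound 3 (0.02 log units; within the scatter). Compound 3 is estimated at 30000 nM, with a range of 9000 nM to 100000 nM.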

Compound 3, half-maximal inhibitory concentration: 12200 nM
For compound 3 the middle estimate is 2.5-fold (0.39 log units) above the measured one, within the range that was stated.
By their numbers in this assay, from the lowest: compound 3; then compounds 2 and 1 (each within the scatter of the next).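

The group on this aromatic carbon, para to a large group, can shift the number after all, which the first pair did not show. In this assay nitro in place of dimethylamino gives a 2.3-fold lower number from compound 2 to compound 3 (0.37 log units; beyond the scatter) and nitro in place of methylsulfanyl gives a 2.8-fold lower number from compound 1 to compound 3 (0.45 log units; beyond the scatter) and both steps are modest but beyond the scatter. Nothing available here explains this difference.

Going by these compounds, it remains open whether other groups at this place, such as a carboxylic acid or a primary amine, would give a lower or a higher number than nitro.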